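The source may report more compounds than this note shows. Statements on the series, on what has been measured and on what is new or still open speak of the compounds shown alone.

Compound 1 `O=C(O)[C@@H]1CCCN1C(=O)CN(c1nc(Cl)nc2[nH]cnc12)C1CC1` gives 26% in a functional assay on the whole organism (Tail, strain ICR) with Mus musculus as the target, in the tail flick test, with a stated time of 90 min, at a dose of 25 umol/kg by the oral route; on this read-out lower numbers stand for a weaker effect and higher numbers for a stronger effect at the one dose given.
Compound 2 `N=C(N)NCCC[C@H](NC(=O)CN(c1nc(Cl)nc2[nH]cnc12)C1CC1)C(=O)OCc1ccccc1` gives 30.4% in this assay.
Compound 3 `CC(C)[C@H](NC(=O)CN(c1ncnc2c1ncn2C1CCCCO1)C1CC1)C(=O)OCc1ccccc1` gives 30.1% in this assay.

The three measured compounds share a core and differ in the amino-acid-derived portion. In this assay, compound 2 stands at the highest of the three numbers, but the gap to compound 3 and the gap to compound 1 both fall within the usual scatter of repeated measurements of this kind, so no order among the three can be claimed from these numbers alone. Within the data shown here, none of the pairs differs in only one place, so no single step between measured compounds is available.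

Compound 4 `C[C@@H](O)[C@H](NC(=O)CN(c1nc(Cl)nc2[nH]cnc12)C1CC1)C(=O)OCc1ccccc1` has not yet been measured. It differs from compound 2 by a group of 3 heavy atoms (2 carbon, 1 oxygen; no ring) in place of a group of 7 heavy atoms (4 carbon, 3 nitrogen; no ring), on a saturated chain carbon bound to an amide-type nitrogen and a carbonyl carbon. As the three measured numbers sit close together in this assay despite sizeable differences in that portion of the molecule, the expected step from compound 2 to compound 4 is a number 1.4 percentage points lower from compound 2 to compound 4 (within the scatter), that is, none beyond the scatter. Compound 4 is therefore estimated to give 29% in this assay, with an expected range from 18% to 40%.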

Compound 4, a percentage reported as activity, at one dose (the size of the read-out at that dose, not a potency): 29.9%
Compound 4: middle estimate off by 0.9 percentage points, on the low side, within the range that was stated.
By their numbers in this assay, from the lowest: compounds 1, 4, 3 and 2 (each within the scatter of the next).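

Among these compounds, compound 2 and compound 4 form the first pair that differs in one place, so the effect of a change on a saturated chain carbon bound to an amide-type nitrogen and a carbonyl carbon can now be read directly. In this assay, replacing the group of 7 heavy atoms (4 carbon, 3 nitrogen; no ring) with 1-hydroxyethyl gives a number 0.5 percentage points lower from compound 2 to compound 4 (within the scatter), so this read-out does not separate the two groups, even though the entering group is much smaller and brings 1 defined stereocentre. No measurement shown here explains this result.

On these data alone, what a methyl, an amine or a longer carbon chain would give on this same carbon remains open, as does the result for the opposite configuration of the 1-hydroxyethyl group. The comparison also rests on a single dose and a single time point, so it leaves open whether compound 2 and compound 4 would still match at other doses or times in the tail-withdrawal read-out of this assay.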